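Hydroxymethyl to ethoxycarbonyl: projection for compound 4

This account rests on a few compounds, and the source may have more. Where it says the series, first, only, none or still open, it means among the compounds named here.

Measured so far:
compound 1 `C/C=C/C(=O)Nc1ccc(Cn2nc(-c3ccc(Oc4ccccc4)cc3)cc2C(=O)OCC)cc1`: > 60000 nM (a limit)
compound 2 `C/C=C/C(=O)Nc1cccc(Cn2nc(-c3ccc(Oc4ccccc4)cc3)cc2CO)c1`: 8100 nM
compound 3 `C/C=C/C(=O)Nc1ccc(Cn2nc(-c3ccc(Oc4ccccc4)cc3)cc2CO)cc1`: 48400 nM

All numbers come from a functional assay on Maver1 cells (Homo sapiens) for inhibition, read by luminescence and CellTiter-Glo, with a stated time of 72 h; on this read-out lower numbers stand for stronger inhibition and higher numbers for weaker inhibition. For compound 1 the assay reports only a limit, not a number, namely (the limit of > 60000 nM in this assay, at which 1 of the 3 values shown sits). Compound 2 and compound 3 share the same atoms joined differently; the difference between the two cores is not broken down here. Compound 2 holds the lowest of the two numbers in this assay, and compound 3 sits beyond the scatter above it.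

Within the core of compound 3, the change ethoxycarbonyl in place of hydroxymethyl on an aromatic carbon produced an at least 1.2-fold higher number from compound 3 to compound 1 (0.09 log units; that floor lies within the scatter). The same change, (ethoxycarbonyl in place of hydroxymethyl on an aromatic carbon), leads from compound 2 to compound 4 `C/C=C/C(=O)Nc1cccc(Cn2nc(-c3ccc(Oc4ccccc4)cc3)cc2C(=O)OCC)c1`, which is not yet measured.

Compound 4 is expected to give about 25000 nM in this assay, with a likely range from 8000 nM to 80000 nM. That expectation means a step of a 3.1-fold higher number from compound 2 to compound 4 (0.49 log units; beyond the scatter), which is set alongside an at least 1.2-fold higher number from compound 3 to compound 1 (0.09 log units; that floor lies within the scatter) and rests on compound 2 at 8100 nM. The upper end of the range is kept wide.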

Compound 4, half-maximal inhibitory concentration: 14200 nM
Beside the measured number, compound 4's estimate is 1.8-fold (0.25 log units) above it; low and high end bracket the measured number.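

In this assay, ethoxycarbonyl in place of hydroxymethyl gives a 1.8-fold higher number from compound 2 to compound 4 (0.24 log units; within the scatter), so on this core the change stays within the usual scatter. Whether the change carries over from one core to the other with the same size cannot be settled: the same change on two cores in this assay, an at least 1.2-fold higher number (0.09 log units; that floor lies within the scatter) from compound 3 to compound 1 and a 1.8-fold higher number (0.24 log units; within the scatter) from compound 2 to compound 4; the limit leaves it open whether they differ With ethoxycarbonyl kept, 3-(((prop-1-en-1-yl)carbonyl)amino)phenyl in place of 4-(((prop-1-en-1-yl)carbonyl)amino)phenyl gives an at least 4.2-fold lower number from compound 1 to compound 4 (0.62 log units; beyond the scatter), but that size is only a floor resting on a limit: the limit of > 60000 nM in this assay, at which 1 of the 4 values shown sits.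

Going by these compounds, what a carboxylic acid or a primary amide would give on the same aromatic carbon stays open. Also open, on these data alone, is how a methyl ester would compare with ethoxycarbonyl on either core.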